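A Methyl on a Phenolic Oxygen Across Four Compounds

A few compounds are considered here, and "the series" means these few. Any claim that something is new, unique, unknown or untested is made for them only; others in the source may bear on it.

Compound 1 `O=C(/C=C/c1ccc(OCCCCCO[N+](=O)[O-])c(O)c1)OCCCCCO[N+](=O)[O-]`, compound 2 `O=C(/C=C/c1ccc(OCCCCO[N+](=O)[O-])c(O)c1)OCCCCO[N+](=O)[O-]` and compound 3 `COc1cc(/C=C/C(=O)OCCCCCO[N+](=O)[O-])ccc1OCCCCCO[N+](=O)[O-]` were tested in a functional assay on NCI-H157 cells (Homo sapiens) for cytotoxicity, read by resazurin assay, with a stated time of 72 h; a lower number here means a stronger inhibitor, a higher number a weaker inhibitor. For compound 1 the result is a limit of the assay, > 50000 nM. For compound 2 the result is likewise a limit, > 50000 nM. For compound 3 the result is also a limit, > 50000 nM. The difference between the cores of compound 1 and compound 2 is not broken down here. Compound 3 differs from compound 1 by methyl in place of hydrogen on an oxygen on an aromatic ring, and the step that the two limits leave unreadable from compound 1 to compound 3 stays unreadable, as shown by the limit of > 50000 nM in this assay, at which 3 of the 3 values shown sit. Compound 4 `COc1cc(/C=C/C(=O)OCCCCO[N+](=O)[O-])ccc1OCCCCO[N+](=O)[O-]`, not yet measured, differs from compound 2 by methyl in place of hydrogen on an oxygen on an aromatic ring, the same change. Compound 4 is expected to show the step that the limit leaves unreadable from compound 2 to compound 4, resting on compound 1 and compound 3, whose values both sit at a limit. The estimate for compound 4 is 70000 nM, between 40000 nM and 150000 nM.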

Compound 4, half-maximal inhibitory concentration: > 50000 nM
Compound 4: a limit, no number; the forecaster's own chance of this, stated with the estimate: 85%; the middle value does not contradict the limit.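

Compound 2 and compound 4 each give only a limit, so no step can be read between them: the limit of > 50000 nM in this assay, at which 4 of the 4 values shown sit. The compounds shown leave open whether hydroxy to methoxy changes cytotoxicity at all, and how strong any of the four actually is.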